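A few compounds are considered here, and "the series" means these few. Any claim that something is new, unique, unknown or untested is made for them only; others in the source may bear on it.

Working notes on the series. Compound 1 is `CCC(C(=O)NCc1ccc(C(F)(F)F)nc1N1CCC(C)CC1)c1ccc(NS(C)(=O)=O)c(F)c1` and compound 2 is `CC1CCN(c2nc(C(F)(F)F)ccc2CNC(=O)C(c2ccccc2)c2ccc(NS(C)(=O)=O)c(F)c2)CC1`; the two differ only in the group on the saturated chain carbon bound to an aromatic carbon and a carbonyl carbon. In an assay on CHO cells for antagonist activity at transient receptor potential cation channel subfamily V member 1 (Homo sapiens), read by FLIPR (on this read-out higher numbers stand for weaker inhibition and lower numbers for stronger inhibition), compound 1 gives 1.6 nM, and in this assay compound 2 gives 1.3 nM; the two numbers sit side by side, and the step of a 1.2-fold lower number from compound 1 to compound 2 (0.09 log units; within the scatter) shows no separation beyond the scatter. Compound 3 is `Cc1ccccc1C(C(=O)NCc1ccc(C(F)(F)F)nc1N1CCC(C)CC1)c1ccc(NS(C)(=O)=O)c(F)c1`. It departs from compound 2 by methyl in place of hydrogen on an aromatic carbon. Within the data shown here, no measured pair in the set carries this particular change, so the only bearing step is the one from compound 1 to compound 2, which was flat. The prior expectation for compound 3 is therefore a step of about a 1.5-fold higher number from compound 2 to compound 3 (0.19 log units; within the scatter) in this assay, direction undetermined and likely inside the scatter. The estimate for compound 3 in this assay is 2 nM, expected to fall between 0.7 nM and 6 nM.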

Compound 3, inhibition constant: 42.9 nM
Compound 3: middle estimate off by 21-fold (1.33 log units), on the low side; the whole stated range lies below it.
By their numbers in this assay, from the lowest: compounds 2 and 1 (each within the scatter of the next); then compound 3.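

In this assay, methyl in place of hydrogen on an aromatic carbon, ortho to a large group, gives a large step, a 33-fold higher number from compound 2 to compound 3 (1.52 log units; beyond the scatter), so this position is sensitive to a change of a single heavy atom. Measured against the ethyl group, 2-methylphenyl gives a 27-fold higher number from compound 1 to compound 3 (1.43 log units; beyond the scatter), whereas phenyl gave a 1.2-fold lower number from compound 1 to compound 2 (0.09 log units; within the scatter); the flat step between ethyl and phenyl therefore does not extend to 2-methylphenyl. No measurement at hand accounts for this difference.

As far as these compounds go, whether a fluorine atom or a methoxy group on the same aromatic carbon would give a step of similar size remains open. Also open, from the compounds shown here alone, is whether a methyl group elsewhere on the phenyl ring would behave as it does here.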